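The source may hold more compounds than are shown below. What is called first, only, known or untested is meant among the compounds shown, and "the series" means these compounds.

Measured so far in an assay for binding affinity to Alpha-1D adrenergic receptor (Homo sapiens), read by radioligand binding; on this read-out higher numbers stand for weaker inhibition and lower numbers for stronger inhibition:
- compound 1, `COc1ccc(S(C)(=O)=O)c(NCC2=NCCN2)c1`: 7590 nM
- compound 2, `CSc1ccc(F)cc1NCC1=NCCN1`: 6.17 nM
- compound 3, `COc1ccc(SC)c(NCC2=NCCN2)c1`: 107 nM

Compound 3 stands second highest of the three numbers in this assay; the steps from it to both neighbours are beyond the scatter. The step of a 71-fold lower number from compound 1 to compound 3 (1.85 log units; beyond the scatter) concerns the methylsulfanyl group, which compound 3 and compound 4 share, and so does not bear on the next change. The step of a 17-fold higher number from compound 2 to compound 3 (1.24 log units; beyond the scatter) does: it shows that the group at the position now varied moves the number strongly, with fluoro giving the lowest number of the set.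

Compound 4, `CSc1ccc(C(F)(F)F)cc1NCC1=NCCN1`, differs from compound 3 by trifluoromethyl in place of methoxy on an aromatic carbon. For the measured compounds named here, with fluoro at this position giving a much lower number than methoxy, a trifluoromethyl group is expected to land nearer to compound 2 than to compound 3, though the size of that move is uncertain, since no trifluoromethyl analogue has been measured. The expected step is a 7.1-fold lower number from compound 3 to compound 4 (0.85 log units; beyond the scatter), a lower number. For compound 4 the estimate in this assay is 15 nM, with a range from 3 nM to 80 nM.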

Compound 4, inhibition constant: 479 nM
Compound 4: the middle estimate sits 32-fold (1.50 log units) below what was measured; the measured number lies above the stated range.
By their numbers in this assay, from the lowest: compound 2; then compound 3; then compound 4; then compound 1.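

At the position para to the methylsulfanyl group, trifluoromethyl in place of methoxy raises the number in this assay (a 4.5-fold higher number from compound 3 to compound 4 (0.65 log units; beyond the scatter)), so the low number of compound 2 does not carry over to this other fluorine-bearing group. Trifluoromethyl in place of fluoro gives a large rise (a 78-fold higher number from compound 2 to compound 4 (1.89 log units; beyond the scatter)), which puts the three groups in the order fluoro, methoxy, trifluoromethyl from lowest number to highest, with fluoro and trifluoromethyl at opposite ends. No measured property of these compounds is available to account for that order.

Open, on these data alone, is whether chloro, a nitrile or an amine at this position would fall nearer to compound 2 or to compound 4. Also open, as far as these compounds go, is whether the same order holds with methylsulfonyl in place of methylsulfanyl, a group carried here by compound 1 alone.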